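Bromine for dichloro on the aryl ether of compound 2

A few compounds are considered here, and "the series" means these few. Any claim that something is new, unique, unknown or untested is made for them only; others in the source may bear on it.

Compound 2 `NC1=NC2(CCOCC2)N(OCCCOc2ccc(Cl)c(Cl)c2)C(N)=N1` stands in an assay on isolated protein for inhibition of Dihydrofolate reductase (Homo sapiens), read by spectrophotometry, using NADPH, with stated times of 5 s and 6 min, tested at 5 uM (a higher number here means a stronger effect of the compound at the concentration tested, a lower number a weaker effect), only at a limit, > 90%, and not at a number (the limit of > 90% in this assay, at which 1 of the 3 values shown sits). Compound 1 `NC1=NC2(CCOCC2)N(OCCCOc2cccc(Cl)c2)C(N)=N1` gives 83.2% in this assay, and compound 3 `NC1=NC2(CCOCC2)N(OCCCOc2ccccc2Cl)C(N)=N1` gives 83.3%. The measured steps around compound 2 are a number at least 6.8 percentage points higher from compound 1 to compound 2 (that floor lies within the scatter) and a number at least 6.7 percentage points lower from compound 2 to compound 3 (that floor lies within the scatter), both with floors inside the scatter. Compound 4 `NC1=NC2(CCOCC2)N(OCCCOc2cccc(Br)c2)C(N)=N1` differs from compound 2 in one place: 3-bromophenyl in place of 3,4-dichlorophenyl on an oxygen on a saturated carbon. The nearest guide is compound 1, whose 3-chlorophenyl gives 83.2%. A modest fall a number at least 6 percentage points lower from compound 2 to compound 4 (that floor lies within the scatter) is therefore expected, at or just beyond the scatter. Compound 4 is estimated at 84%, in a range from 72% to 94%.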

Compound 4, a percentage reported as inhibition, at one concentration (the size of the read-out at that concentration, not a potency): 86.7%
The estimate for compound 4 lay 2.7 percentage points below the measured number; the range from low to high includes it.
By their numbers in this assay, from the lowest: compounds 1, 3 and 4 (each within the scatter of the next). At a limit, above all of these: compound 2.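

Bromo in place of chloro on an aromatic carbon gives a number 3.5 percentage points higher from compound 1 to compound 4 (within the scatter), and 3-bromophenyl in place of 2-chlorophenyl gives a number 3.4 percentage points higher from compound 3 to compound 4 (within the scatter), so the three aryl ethers with a single halogen cannot be told apart at this position. Against 3,4-dichlorophenyl the step is a number at least 3.3 percentage points lower from compound 2 to compound 4 (that floor lies within the scatter), which does not separate 3-bromophenyl from that group. Compound 2 stands only at a limit: the limit of > 90% in this assay, at which 1 of the 4 values shown sits.

Going by these compounds, its actual number remains open. So does the read-out with an amine or a carboxylic acid on this aromatic ring, or with a longer chain on the oxygen.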